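This account rests on a few compounds, and the source may have more. Where it says the series, first, only, none or still open, it means among the compounds named here.

In a functional assay on PC-3 cells (Homo sapiens) for inhibition, read by MTT assay, with a stated time of 24 h, tested at 10 ug/mL (a lower number here means less inhibition of growth, a higher number more inhibition of growth at the concentration tested), compound 1 `O=C(CCCCC1CCSS1)Nc1cccc(C(F)(F)F)c1` gives 38.5%, while compound 2 `O=C(CCCCC1CCSS1)Nc1ccc([N+](=O)[O-])c(C(F)(F)F)c1`, which carries a nitro group, is reported as "not active" (no number reported). On these data alone, compound 3 `O=C(CCCCC(S)CCS)Nc1cccc(C(F)(F)F)c1` has no number to serve as a starting point: its entry reads "not determined" (no result reported), so its standing in this assay is unknown.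

The remaining structure, compound 4 `O=C(CCCCC(S)CCS)Nc1ccc([N+](=O)[O-])c(C(F)(F)F)c1`, is reached from it by one change: nitro in place of hydrogen on an aromatic carbon. This places nitro in place of hydrogen on an aromatic carbon, ortho to a trifluoromethyl group and para to a large group.

A step toward less inhibition of growth is expected, moderate in size but beyond the usual scatter. This expectation rests only on compound 2 at "not active" (no number reported) set against compound 1 at 38.5%. That pair has a different side chain from compound 4, so the transfer is uncertain and the range is kept wide. A report of no activity would not be surprising. For compound 4 the estimated value is 15%, with an expected range from 0% to 35%.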

Compound 4, percent growth inhibition at one concentration: 45.5%
The estimate for compound 4 lay 30.5 percentage points below the measured number, and the stated range ends below it.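

No step can be read from compound 3 to compound 4: in this assay compound 3 stands at "not determined" (no result reported), with no number to set against compound 4 at 45.5%. No supporting evidence bears on this result. The compounds shown leave open what nitro in place of hydrogen does with this open side chain.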